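The source may report more compounds than this note shows. Statements on the series, on what has been measured and on what is new or still open speak of the compounds shown alone.

Measured so far:
Compound 1, `COc1c(N2CCC(C)(N)C2)c(F)cc2c(=O)c(C(=O)O)cn(C3CC3)c12`, gives 38 ug/mL in a functional assay on V79 cells (Cricetulus griseus) for cytotoxicity, read by colony formation; a higher number here means a weaker inhibitor, a lower number a stronger inhibitor.
Compound 2, `COc1c(N2CCC(C)(N)C2)c(F)cc2c(=O)c(C(=O)O)cn(-c3ccc(F)cc3F)c12`, gives 250 ug/mL in this assay.
Compound 3, `CC1CN(c2c(F)cc3c(=O)c(C(=O)O)cn(C4CC4)c3c2Cl)CCN1`, gives 45 ug/mL in this assay.

Compound 1 and compound 2 share one core and differ in a single group:
2,4-difluorophenyl in place of cyclopropyl on an aromatic nitrogen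
That exchange brought a 6.6-fold higher number from compound 1 to compound 2 (0.82 log units; beyond the scatter), so the compound with the new group came out as the weaker inhibitor in this assay. Compound 3 carries a different core; the difference between the two cores is not broken down here. Its value and that of compound 1 lie within the usual scatter of each other, so nothing separates them. Compound 4, `CC1CN(c2c(F)cc3c(=O)c(C(=O)O)cn(-c4ccc(F)cc4F)c3c2Cl)CCN1`, is the counterpart of compound 3 in which the same exchange has been made:
2,4-difluorophenyl in place of cyclopropyl on an aromatic nitrogen
The group that leaves, the group that enters and the surroundings of the place read exactly as they do between compound 1 and compound 2, so this is the same change carried onto a second core. Among the measured compounds shown here, only one earlier instance of the change is available, and whether it repeats its effect on another core is not guaranteed, so the expectation leans on that single instance alone. For compound 4 a step of a 5.6-fold higher number from compound 3 to compound 4 (0.74 log units; beyond the scatter) is expected in this assay, resting on the measured 6.6-fold higher number from compound 1 to compound 2 (0.82 log units; beyond the scatter). On that basis compound 4 is estimated at 250 ug/mL, with a likely range from 110 ug/mL to 550 ug/mL.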

Compound 4, half-maximal inhibitory concentration: > 500 ug/mL
Compound 4 ended at the assay's limit (the forecaster's own chance of this, stated with the estimate: 10%); at least 2.0-fold (0.30 log units) between middle value and limit.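

The second core tells the same story in direction: putting 2,4-difluorophenyl in place of cyclopropyl on the aromatic nitrogen brought an at least 11-fold higher number from compound 3 to compound 4 (1.04 log units; beyond the scatter), so in this assay the compound with the new group again came out as the weaker inhibitor. Compound 4 gives > 500 ug/mL, and this value is a limit of the assay, not a number. The direction of the change therefore carried over from the core of compound 1 to the core of compound 3, but the size of the step on the second core remains unknown, and two cores are too few to support a rule for the whole series: the same change on two cores in this assay, a 6.6-fold higher number (0.82 log units; beyond the scatter) from compound 1 to compound 2 and an at least 11-fold higher number (1.04 log units; beyond the scatter) from compound 3 to compound 4; the limit leaves it open whether they differ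

The compounds shown leave open how other groups on the aromatic nitrogen, such as an ethyl or an unsubstituted phenyl, would read in this assay, and so whether the two fluorines of the entering ring play any part in the step. They also leave open whether the exchange would keep its direction on a core carrying a different group in place of the methoxy or the chlorine, such as a hydrogen or a methyl, with the amine-bearing ring left unchanged.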